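The source may report more compounds than this note shows. Statements on the series, on what has been measured and on what is new or still open speak of the compounds shown alone.

Compound 1, whose structure is `COc1cc(/C(Cl)=C/C=C(\C#N)C(=O)c2c[nH]c3ccccc23)cc(OC)c1OC`, is the lower of the two numbers recorded in a functional assay on MCF7 cells (Homo sapiens) for cytotoxicity, read by sulforhodamine B assay, with a stated time of 48 h (on this read-out higher numbers stand for weaker inhibition of growth and lower numbers for stronger inhibition of growth), where compound 1 gives 4000 nM. Within the data shown here, the only other measured member of the set, compound 2 with the structure `Cc1[nH]c2ccccc2c1C(=O)/C(C#N)=C/C=C(\Cl)c1ccc(Br)cc1`, gives 73900 nM in this assay, a number that stands well beyond the scatter above that of compound 1; the two compounds differ in several places at once, so their pair says nothing about any single change.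

Compound 3, drawn as `COc1cc(/C(Cl)=C/C=C(\C#N)C(=O)c2c[nH]c3ccc(Br)cc23)cc(OC)c1OC`, has not yet been measured. It differs from compound 1 in one place only: bromo in place of hydrogen on an aromatic carbon. Among the measured compounds shown here, no measured pair in this set isolates such a change, so nothing recorded here fixes its size or direction. In the absence of such a step, compound 3 is expected to stay close to compound 1, with a step from a 1.3-fold lower number from compound 1 to compound 3 (0.12 log units; within the scatter) that is most likely not beyond the scatter, leaning if anything toward a slightly lower number. Compound 3 is therefore estimated at 3000 nM in this assay, within a range from 1000 nM to 12000 nM.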

Compound 3, concentration for 50% growth inhibition: 30800 nM
Beside the measured number, compound 3's estimate is 10-fold (1.01 log units) below it, and the stated range ends below it.
By their numbers in this assay, from the lowest: compound 1; then compound 3; then compound 2.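

In this assay, among these compounds, the change from 1H-indol-3-yl to 5-bromo-1H-indol-3-yl gives a 7.7-fold higher number from compound 1 to compound 3 (0.89 log units; beyond the scatter), the first step in the set that isolates a single place, and it runs toward weaker inhibition of growth. It shows that this aromatic carbon, on the six-membered aromatic ring of carbon only within the fused system, is not indifferent to substitution on the core of compound 1: one added bromine atom is enough to move the number beyond the scatter, and here hydrogen gives the stronger inhibition of growth. No measurement at hand accounts for this step, so its cause remains unknown.

The compounds shown leave open whether the step belongs to bromo itself or would follow any group placed on this carbon, since a single replacement cannot say how fluoro, methoxy or an amine there would read. They also leave open whether the same replacement would carry the same size and direction on another core, such as that of compound 2.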